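This account rests on a few compounds, and the source may have more. Where it says the series, first, only, none or still open, it means among the compounds named here.

Compound 1 `CC1=C(C(=O)Nc2ccc(F)cc2)C(c2ccc(Cl)cc2)n2c(s/c(=C/c3ccc(Br)cc3)c2=O)=N1`: 35%
Compound 2 `CC1=C(C(=O)Nc2ccc(F)cc2)C(c2ccc(Cl)cc2)n2c(s/c(=C/c3ccccc3[N+](=O)[O-])c2=O)=N1`: 16%

In a functional assay on the whole organism (strain albino) for inhibition, with Rattus norvegicus as the target, read by paw edema, with stated times of 1 h and 3 h, at a dose of 25 mg/kg by the oral route (a lower number here means less inhibition, a higher number more inhibition at the dose given (going by the name of the read-out)), compound 1 gives 35%, the higher of the two numbers; compound 2 gives 16%. Compound 3 `CC1=C(C(=O)Nc2ccc(F)cc2)C(c2ccccc2[N+](=O)[O-])n2c(s/c(=C/c3ccc(Br)cc3)c2=O)=N1` differs from compound 1 in one place: 2-nitrophenyl in place of 4-chlorophenyl on a saturated ring carbon. Among the measured compounds shown here, the single measured step, a number 19 percentage points lower from compound 1 to compound 2 (beyond the scatter), brought in 2-nitrophenyl at a different place, on a double-bonded chain carbon bound to an aromatic carbon, so it bears on the present change only loosely. A modest fall is therefore expected, a number 10 percentage points lower from compound 1 to compound 3 (within the scatter). Compound 3 is estimated at 25%, within 10% to 40%.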

Compound 3, a percentage reported as inhibition, in the whole organism at one dose (the size of the read-out at that dose, not a potency): 16%
For compound 3 the middle estimate is 9 percentage points above the measured one; the range from low to high includes it.
By their numbers in this assay, from the lowest: compounds 2 and 3 (each within the scatter of the next); then compound 1.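

Putting 2-nitrophenyl in place of 4-chlorophenyl on the saturated ring carbon gives a number 19 percentage points lower from compound 1 to compound 3 (beyond the scatter) in this assay. This saturated ring carbon therefore responds to a change of its aromatic group, which the earlier step, made on the double-bonded chain carbon, could not show. Nothing measured here explains the change.

Still open, on these data alone, is whether the outcome follows the nitro group itself or its ring position, which 2-chlorophenyl or 4-nitrophenyl at this carbon would separate. Also open, as far as these compounds go, is how unsubstituted phenyl or 4-aminophenyl would read here.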